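The source may report more compounds than this note shows. Statements on the series, on what has been measured and on what is new or still open speak of the compounds shown alone.

Measured so far in an ADME assay on MT4 cells (Homo sapiens) for cytotoxicity, read by MTT assay, with a stated time of 4 days; a higher number here means that more compound is tolerated, a lower number that less compound is tolerated:
compound 1, `Cc1cc(-c2ccc(C#N)cc2)cc(C)c1Nc1ccnc(Nc2ccc(C#N)cc2)n1`, 2080 nM;
compound 2, `Cc1cc(-c2cccc(C(F)(F)F)c2)cc(C)c1Nc1ccnc(Nc2ccc(C#N)cc2)n1`, 4030 nM;
compound 3, `COc1ccccc1-c1cc(C)c(Nc2ccnc(Nc3ccc(C#N)cc3)n2)c(C)c1`, 940 nM.

Compound 1 stands second highest of the three. Its nearest neighbour is compound 2, with a 1.9-fold higher number from compound 1 to compound 2 (0.29 log units; within the scatter), while compound 3 lies further off, with a 2.2-fold lower number from compound 1 to compound 3 (0.34 log units; beyond the scatter), and between those two a 4.3-fold lower number from compound 2 to compound 3 (0.63 log units; beyond the scatter).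

Compound 4, `Cc1cc(-c2ccc(C(F)(F)F)cc2)cc(C)c1Nc1ccnc(Nc2ccc(C#N)cc2)n1`, differs from compound 1 by trifluoromethyl in place of cyano on an aromatic carbon. For the measured compounds named here, the only measured step bearing on this is the one in which 3-(trifluoromethyl)phenyl replaced 4-cyanophenyl, namely a 1.9-fold higher number from compound 1 to compound 2 (0.29 log units; within the scatter), which stayed within the scatter. A trifluoromethyl entering again is therefore expected to move this assay little, if at all beyond the scatter, and the expected step is a 1.4-fold higher number from compound 1 to compound 4 (0.16 log units; within the scatter). Compound 4 is estimated at 3000 nM, between 1500 nM and 6500 nM.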

Compound 4, half-maximal cytotoxic concentration: 4160 nM
Estimate against measurement, compound 4: 1.4-fold (0.14 log units) below; measured number inside the range.
By their numbers in this assay, from the lowest: compound 3; then compounds 1, 2 and 4 (each within the scatter of the next).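

In this assay, trifluoromethyl in place of cyano at this position gives a 2.0-fold higher number from compound 1 to compound 4 (0.30 log units; within the scatter), so the exchange stays within the scatter even with the rest of the phenyl ring unchanged. Both the 4-(trifluoromethyl)phenyl and 3-(trifluoromethyl)phenyl groups are tolerated alike, with a 1.0-fold higher number from compound 2 to compound 4 (0.01 log units; within the scatter), whereas a 4.4-fold higher number from compound 3 to compound 4 (0.65 log units; beyond the scatter) sets compound 3 clearly apart from compound 4. Nothing available explains these numbers.

On these data alone, whether an amine or a carboxylic acid at this position would keep the number in this assay remains open. So does whether the lower number of compound 3 belongs to the methoxy group itself or to where it sits on the ring.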